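The source may report more compounds than this note shows. Statements on the series, on what has been measured and on what is new or still open speak of the compounds shown alone.

Measured compounds:
- Compound 1 `CC(C)(C)[C@]1(c2ccccc2)OCC[C@H](CCNCc2ccccc2)O1`: in an assay on brain for displacement of a labelled ligand from Sigma non-opioid intracellular receptor 1 (Cavia porcellus) (a lower number here means a stronger inhibitor, a higher number a weaker inhibitor), compound 1 gives 253 nM.
- Compound 2 `CC(C)(C)[C@@]1(c2ccccc2)OCC[C@@H](CCN)O1`: in this assay compound 2 gives only a limit, > 10000 nM, not a number.
- Compound 3 `CC(C)(C)[C@@]1(c2ccccc2)OCC[C@@H](CCNCc2ccccc2)O1`: in this assay compound 3 gives 128 nM.

Compound 3 holds the lowest of the two numbers shown, with compound 1 nearest: the step of a 2.0-fold lower number from compound 1 to compound 3 (0.30 log units; within the scatter) stays within the scatter, and the two are mirror images of one another (the fact that compounds 1 and 3 differ only in the configuration as drawn). The other measured step is large: an at least 78-fold lower number from compound 2 to compound 3 (1.89 log units; beyond the scatter), where the value of compound 2 is a limit (the limit of > 10000 nM in this assay, at which 1 of the 3 values shown sits).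

Compound 4 `C[C@@]1(c2ccccc2)OCC[C@@H](CCNCc2ccccc2)O1` keeps the benzyl on the amine nitrogen and all the stereochemistry of compound 3, and differs only at the ring: methyl in place of tert-butyl on a saturated ring carbon. Neither measured step touches this ring carbon; one concerns the configuration, the other the amine substituent. Among the measured compounds shown here, there is therefore no measured step that bears on the change, and the expectation is a step of a 1.3-fold higher number from compound 3 to compound 4 (0.10 log units; within the scatter) in this assay that does not go beyond the scatter, in no set direction. Compound 4 is estimated at 160 nM, within a range from 50 nM to 600 nM.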

Compound 4, inhibition constant: 17 nM
Beside the measured number, compound 4's estimate is 9.4-fold (0.97 log units) above it; measured number outside the range, below it.
By their numbers in this assay, from the lowest: compound 4; then compounds 3 and 1 (each within the scatter of the next). At a limit, above all of these: compound 2.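

In this assay, swapping tert-butyl for methyl on the saturated ring carbon between two ring oxygen atoms gives a 7.5-fold lower number from compound 3 to compound 4 (0.88 log units; beyond the scatter) and so moves the number beyond the scatter. Among the compounds shown here, the earlier compounds tested only the configuration and the amine substituent, so this is the first sign that the group on this ring carbon affects the result, with the smaller of the two groups giving the lower number. Nothing in the information available explains why this change has this effect.

With only tert-butyl and methyl at this ring carbon, two groups cannot establish a trend, and the compounds shown leave open how ethyl, isopropyl or a plain hydrogen there would read. From the compounds shown here alone, it also remains open whether the mirror image of compound 4 would stay within the scatter of compound 4, as compound 1 does of compound 3.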